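A few compounds are considered here, and "the series" means these few. Any claim that something is new, unique, unknown or untested is made for them only; others in the source may bear on it.

In an ADME assay on HaCaT cells (Homo sapiens) for cytotoxicity, read by sulforhodamine B assay, with a stated time of 48 h (a lower number here means that less compound is tolerated, a higher number that more compound is tolerated), compound 1 `CCCCCCCCCCCCCCCCCC(=O)N1CCOCC1` gives 41.5 ug/mL. Compound 3 `CCCCCCCCCCCCCCCC(=O)N1CCOCC1` gives 28.9 ug/mL, which is level with compound 1 within the scatter, and compound 2 `CCCCC/C=C\C/C=C\CCCCCCCC(=O)N1CCCCC1` gives a clearly lower 4.2 ug/mL. The next structure, compound 4 `CCCCCCCCCCCCCCCCCC(=O)N[C@@H](C)c1ccccc1`, keeps the chain of compound 1 but changes the group on the carbonyl carbon: (1-phenylethyl)amino in place of morpholin-4-yl on a carbonyl carbon. Among the measured compounds shown here, no measured step makes this kind of change on its own. The only one available, a 1.4-fold lower number from compound 1 to compound 3 (0.16 log units; within the scatter), alters the chain and stays within the scatter, so it says little about the new group. Compound 2 differs from compound 1 in more than one place, so the value of compound 2, 4.2 ug/mL, cannot be assigned to the amide group alone, but it does show that this series can reach much lower numbers. A modest fall is therefore expected, with a wide margin on the low side. The estimated change is a 1.7-fold lower number from compound 1 to compound 4 (0.22 log units; within the scatter), which is small and uncertain. For compound 4 the expected value is 25 ug/mL, with an estimated range of 6 ug/mL to 90 ug/mL.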

Compound 4, concentration lethal to 50% of the cells: 69.5 ug/mL
Compound 4: middle estimate off by 2.8-fold (0.44 log units), on the low side, within the range that was stated.
By their numbers in this assay, from the lowest: compound 2; then compounds 3, 1 and 4 (each within the scatter of the next, the first and the last beyond it).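

In this assay the step of (1-phenylethyl)amino in place of morpholin-4-yl on a carbonyl carbon is a 1.7-fold higher number from compound 1 to compound 4 (0.22 log units; within the scatter) and so the two compounds stand level. Among the compounds shown here, this is the first step read at this position, and it shows that a group of 9 heavy atoms with an aromatic ring, an amide hydrogen and a defined stereocentre can replace the morpholine ring on the same chain without a shift beyond the scatter. Nothing available explains this result.

On these data alone, whether piperidin-1-yl on the saturated chain of compound 1 would stand level as well, or would come closer to compound 2 at 4.2 ug/mL, remains open. So does the outcome for benzylamino, which lacks the methyl group and the stereocentre of (1-phenylethyl)amino, and for the opposite form of that stereocentre.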